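Sulfonamide series: methoxy to methyl, expectation for compound 3

The source may hold more compounds than are shown below. What is called first, only, known or untested is meant among the compounds shown, and "the series" means these compounds.

Compound 2 `COc1ccc(S(=O)(=O)Nc2cccnc2)c(OC)c1` has no result in an assay on isolated protein for inhibition of alkaline phosphatase, tissue-nonspecific isozyme (Homo sapiens); a higher number here means a weaker inhibitor, a lower number a stronger inhibitor; it stands as "not determined" (no result reported). Compound 1 `CNC(=O)c1cncc(NS(=O)(=O)c2cc(Cl)ccc2OC)c1` sits at the assay limit in this assay, giving > 20000 nM, which is a limit and not a number. Of the values shown, one is the limit of > 20000 nM in this assay, at which 1 of the 2 values shown sits. Compound 3 `COc1cc(C)ccc1S(=O)(=O)Nc1cccnc1` differs from compound 2 by methyl in place of methoxy on an aromatic carbon. Among the measured compounds shown here, no measured step connects any two compounds, so the size of the step in this assay is unknown; none beyond the scatter is expected in either direction. Compound 3 is estimated at 20000 nM, within 5000 nM to 80000 nM.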

Compound 3, half-maximal inhibitory concentration: 3550 nM
Estimate against measurement, compound 3: 5.6-fold (0.75 log units) above; the measured number lies below the stated range.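

No new step can be read between compound 2 and compound 3, as compound 2 carries no number in this assay. Whether methyl in place of methoxy changes inhibition stays open, and nothing shown bears on the value of compound 3.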